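Triazole substituent on the shared core: aryl to acetoxymethyl

The source may hold more compounds than are shown below. What is called first, only, known or untested is meant among the compounds shown, and "the series" means these compounds.

Going by the values given here, compound 1 `CCS[C@@H]1[C@H](SCC)[C@@H](Cn2cc(-c3ccc(F)cc3)nn2)O[C@H]1n1ccc(=O)[nH]c1=O` is the only member of the series with a number in a functional assay on HepG2 cells (Homo sapiens) for cytotoxicity, read by MTT assay, with a stated time of 72 h; a higher number here means that more compound is needed for the effect, a lower number that less compound is needed; in this assay compound 1 gives 22600 nM. Compound 2 `CCOC(=O)c1cn(C[C@H]2O[C@@H](n3ccc(=O)[nH]c3=O)[C@H](SCC)[C@@H]2SCC)nn1` sits at a limit of this assay and not at a number: in this assay compound 2 gives >= 100000 nM. Among the compounds with values here, the one measured step, an at least 4.4-fold higher number from compound 1 to compound 2 (0.64 log units; beyond the scatter), therefore shows that replacing the 4-fluorophenyl with a group that has no ring costs activity, with the new value reaching (the limit of >= 100000 nM in this assay, at which 1 of the 2 values shown sits).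

Compound 3 `CCS[C@@H]1[C@H](SCC)[C@@H](Cn2cc(COC(C)=O)nn2)O[C@H]1n1ccc(=O)[nH]c1=O` differs from compound 1 by acetoxymethyl in place of 4-fluorophenyl on an aromatic carbon. The entering acetoxymethyl, like the ethoxycarbonyl of compound 2, has no ring and carries 1 double bond outside aromatic rings and 2 hydrogen-bond acceptors, so the step from compound 1 to compound 2 is the one that bears on this change. A step in the same direction, toward a higher number, is expected, and of comparable size, possibly again ending at the limit.

Compound 3 is therefore expected to give 70000 nM in this assay, with a range from 25000 nM to 200000 nM; the expected step is a 3.1-fold higher number from compound 1 to compound 3 (0.49 log units; beyond the scatter).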

Compound 3, half-maximal effective concentration: >= 100000 nM
Compound 3: no number, only a limit; the forecaster's own chance of this, stated with the estimate: 50%; middle value at least 1.4-fold (0.15 log units) away from the limit.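

In this assay, the loss on leaving 4-fluorophenyl now appears with a second group without a ring on this aromatic carbon of the five-membered aromatic ring with 3 nitrogen: an at least 4.4-fold higher number from compound 1 to compound 3 (0.64 log units; beyond the scatter) is the step, so the earlier result no longer rests on ethoxycarbonyl alone. Compound 3 gives >= 100000 nM in this assay, which is a limit and not a number. The steps between the two limits cannot be read, so no order between acetoxymethyl and ethoxycarbonyl can be given, and the comparison in this series ends here: the limit of >= 100000 nM in this assay, at which 2 of the 3 values shown sit.

Compound 1, with 22600 nM, remains the only number in the series, and the compounds shown do not separate the part played by the fluorine from that of the six-membered aromatic ring, a question a plain phenyl would address. On these data alone, whether any group without a ring comes back under the limit also stays open, for instance a butyl chain or an aminomethyl.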